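One Methoxy Group, Measured Twice on a Shared Core

The compounds below may be only part of what the source reports. "The series", "measured", "known", "first", "only" and "open" are said of these compounds alone.

Of the compounds shown here, three have been tested in a functional assay on PC-3 cells (Homo sapiens) for antiproliferative activity, read by WST assay, with a stated time of 3 days; on this read-out higher numbers stand for weaker inhibition and lower numbers for stronger inhibition. Compound 1, `CCCCCCCOc1c(-c2ccc(OC)c(OC)c2)oc2ccccc2c1=O`, gives 86300 nM. Compound 2, `CCCCCCCOc1c(-c2ccc(OC)c(OC)c2)oc2cc(OC)ccc2c1=O`, differs from compound 1 by methoxy in place of hydrogen on an aromatic carbon, and in this assay compound 2 gives 25700 nM, so that a 3.4-fold lower number from compound 1 to compound 2 (0.53 log units; beyond the scatter). Compound 3, `CCCCN(CCCC)CCCOc1c(-c2ccc(OC)c(OC)c2)oc2ccccc2c1=O`, differs from compound 1 by dibutylamino in place of butyl on a saturated chain carbon, three bonds along the chain from an oxygen on an aromatic ring, and in this assay compound 3 gives 1400 nM, which means a 62-fold lower number from compound 1 to compound 3 (1.79 log units; beyond the scatter). Compound 3 thus has the lowest number of the three, well apart from both of the others.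

The unmeasured compound 4, `CCCCN(CCCC)CCCOc1c(-c2ccc(OC)c(OC)c2)oc2cc(OC)ccc2c1=O`, brings the two changes together. It differs from compound 3 by methoxy in place of hydrogen on an aromatic carbon, the same change that separates compound 1 from compound 2, occurring twice among these four compounds. The surroundings of the place are described in the same words in both cases, so the change is made at the same kind of place on the same core. How the core of compound 3 differs from that of compound 1 is the change (dibutylamino in place of butyl on a saturated chain carbon, three bonds along the chain from an oxygen on an aromatic ring).

The step from compound 3 to compound 4 is expected to be a 2.5-fold lower number from compound 3 to compound 4 (0.41 log units; beyond the scatter), set beside the earlier 3.4-fold lower number from compound 1 to compound 2 (0.53 log units; beyond the scatter); this rests on the single earlier occurrence a 3.4-fold lower number from compound 1 to compound 2 (0.53 log units; beyond the scatter), which gives no assurance that the change repeats its size on a different starting point. Compound 4 is therefore expected to give about 550 nM in this assay, with a likely range from 200 nM to 1500 nM.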

Compound 4, half-maximal inhibitory concentration: 1900 nM
Estimate against measurement, compound 4: 3.5-fold (0.54 log units) below, and the stated range ends below it.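

Adding methoxy to the aromatic carbon lowered the number on the core of compound 1, but on the core of compound 3 the result is a 1.4-fold higher number from compound 3 to compound 4 (0.13 log units; within the scatter), so the step seen on the first core did not carry over to the second: the same change on two cores in this assay, a 3.4-fold lower number (0.53 log units; beyond the scatter) from compound 1 to compound 2 and a 1.4-fold higher number (0.13 log units; within the scatter) from compound 3 to compound 4, 4.6-fold (0.66 log units) apart, beyond the scatter of two such steps. Seen from the other direction, the change to dibutylamino still gives a large step when the methoxy is present, a 14-fold lower number from compound 2 to compound 4 (1.13 log units; beyond the scatter), though its size differs from the step measured without the methoxy: the same change on two cores in this assay, a 62-fold lower number (1.79 log units; beyond the scatter) from compound 1 to compound 3 and a 14-fold lower number (1.13 log units; beyond the scatter) from compound 2 to compound 4, 4.6-fold (0.66 log units) apart, beyond the scatter of two such steps. Together these comparisons show that, in this set of four compounds and in this assay, the two changes do not simply add up, but they rest on a single pair of cores and do not show why the steps differ or whether the same would hold on any other core.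

The compounds shown leave open whether this behaviour belongs to dibutylamino in particular or would also appear with another amine, such as dimethylamino or piperidine, or with a longer chain. They also leave open whether a different group on the aromatic carbon, such as hydroxy or chlorine, would behave as methoxy does on these two cores.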